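The source may hold more compounds than are shown below. What is called first, only, known or untested is meant among the compounds shown, and "the series" means these compounds.

Compound 1, `Cc1nc(-c2ccc(Cl)cc2)sc1C(=O)CSc1nc(-c2ccc(Cl)c(Cl)c2)c(C#N)c(=O)[nH]1`, was tested in a functional assay on U-87MG ATCC cells for antiproliferative activity against U-87 MG (Homo sapiens), read by MTT assay, with a stated time of 48 h, tested at 5 uM (on this read-out higher numbers stand for a weaker effect at the one concentration tested and lower numbers for a stronger effect), and gave 101%. Among the three compounds measured, compound 1 shows the highest number in this assay; the nearest is compound 3, `COc1cccc(-c2nc(SCC(=O)c3sc(-c4ccccc4)nc3C)[nH]c(=O)c2C#N)c1`, which gives 99%, a gap within the usual scatter, while the furthest is compound 2, `Cc1nc(-c2ccc(Cl)cc2)sc1C(=O)CSc1nc(N)c(C#N)c(-c2ccc(Cl)cc2)n1`, which gives 46.1%, a gap well beyond the scatter. Compound 1 and compound 3 thus show essentially no effect at the tested concentration, whereas compound 2 clearly does.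

The unmeasured compound 4, `COc1ccc(-c2nc(SCC(=O)c3sc(-c4ccc(Cl)cc4)nc3C)[nH]c(=O)c2C#N)cc1`, differs from compound 1 in one place: 4-methoxyphenyl in place of 3,4-dichlorophenyl on an aromatic carbon. Compound 3 already carries a methoxyphenyl group at a comparable part of the shared core and gives 99%, which suggests that this kind of exchange leaves the read-out near the top of the scale. No step beyond the scatter is therefore expected in this assay, and the expected step of a number 4 percentage points lower from compound 1 to compound 4 (within the scatter) is essentially flat. Compound 4 is expected to give about 97%, with a plausible range from 85% to 108%.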

Compound 4, a percentage reported as activity, at one concentration (the size of the read-out at that concentration, not a potency): 92.1%
Compound 4: middle estimate off by 4.9 percentage points, on the high side; the measured number falls inside the stated range.
By their numbers in this assay, from the lowest: compound 2; then compounds 4, 3 and 1 (each within the scatter of the next).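

In this assay, replacing 3,4-dichlorophenyl with 4-methoxyphenyl on the aromatic carbon next to the ring nitrogen and ortho to a cyano group gives a number 8.9 percentage points lower from compound 1 to compound 4 (within the scatter). This one-place comparison, the first available here, shows that the position accepts this change without a step beyond the scatter, even though the entering group carries a hydrogen-bond acceptor and the leaving group carries none. No measured evidence bears on why the read-out holds here.

As far as these compounds go, whether an amine or a carboxylic acid on this aromatic carbon would shift the read-out in this assay remains open. From the compounds shown here alone, it is also open whether a smaller change, such as a single chlorine on the phenyl ring, would behave in the same way.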